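The compounds below may be only part of what the source reports. "The series", "measured", "known", "first", "only" and "open" are said of these compounds alone.

The set holds four compounds built around two related cores. Compound 1 `COc1cc(/C=C2\CN(C)C/C(=C\c3cccnc3)C2=O)cc(OC)c1` and compound 3 `COc1cc(/C=C2\CN(C)C/C(=C\c3ccncc3)C2=O)cc(OC)c1` share one core, while compound 2 `CN1C/C(=C\c2ccc(C(F)(F)F)cc2)C(=O)/C(=C/c2cccnc2)C1` and compound 4 `CN1C/C(=C\c2ccncc2)C(=O)/C(=C/c2ccc(C(F)(F)F)cc2)C1` share another; the difference between the two cores is not broken down here. In an ADME assay on L02 cells (Homo sapiens) for cytotoxicity, read by MTT assay, with a stated time of 24 h (on this read-out higher numbers stand for weaker inhibition and lower numbers for stronger inhibition), compound 1 gives 18400 nM. In this assay compound 3 gives 13400 nM. In this assay compound 2 gives 15600 nM. The three measured numbers sit close together, and every gap among them is within the scatter of such measurements, so no order can be read from them.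

Compound 3 differs from compound 1 by a single change (pyridin-4-yl in place of pyridin-3-yl on a double-bonded chain carbon bound to a double-bonded ring carbon). That change produced a 1.4-fold lower number from compound 1 to compound 3 (0.14 log units; within the scatter), a step that stays within the scatter. Compound 4 differs from compound 2 by the same kind of change (pyridin-4-yl in place of pyridin-3-yl on a double-bonded chain carbon bound to a double-bonded ring carbon), made at the same kind of place. Because the earlier step of a 1.4-fold lower number from compound 1 to compound 3 (0.14 log units; within the scatter) was small, a step of similar size is expected in this assay, and the estimate here means a 1.3-fold lower number from compound 2 to compound 4 (0.11 log units; within the scatter). That expectation rests on one earlier instance only, so the range around it is kept wide. Compound 4 is therefore expected to give about 12000 nM in this assay, with a likely range from 6000 nM to 25000 nM.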

Compound 4, half-maximal inhibitory concentration: 17400 nM
The estimate for compound 4 lay 1.5-fold (0.16 log units) below the measured number; the range from low to high includes it.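

The step for the swap on the second core is a 1.1-fold higher number from compound 2 to compound 4 (0.05 log units; within the scatter), so in this assay pyridin-4-yl in place of pyridin-3-yl leaves no readable mark on this core, as it left none on the core of compound 1. Set side by side, the two instances of the change do not differ: the same change on two cores in this assay, a 1.4-fold lower number (0.14 log units; within the scatter) from compound 1 to compound 3 and a 1.1-fold higher number (0.05 log units; within the scatter) from compound 2 to compound 4, 1.5-fold (0.19 log units) apart, within the scatter of two such steps This shows that, in these two pairs and on this read-out, the change carried from one core to the other without a step that can be told from repeat-measurement noise, but it does not show that the change is without effect in general, and the opposite directions of the two small steps carry no meaning, since two pairs within the scatter can support neither a rule nor a difference between the cores.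

The compounds shown leave open whether pyridin-2-yl, or a phenyl ring bearing an amine or a carboxylic acid, on a double-bonded chain carbon bound to a double-bonded ring carbon would also stay within the scatter of these values. They also leave open whether the same swap would stay this quiet on a third core or on any other read-out.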